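The source may hold more compounds than are shown below. What is called first, only, known or untested is meant among the compounds shown, and "the series" means these compounds.

Compound 1 `CSc1cccc(N2C(=O)CN(c3ccc(C(F)(F)F)cc3)CC2C(=O)NC2CCCC2)c1`: 10000 nM
Compound 2 `O=C(NC1CCCC1)C1CN(c2ccc(C(F)(F)F)cc2)CC(=O)N1c1ccc2ccoc2c1`: 20000 nM

Only these two compounds have been measured in an ADME assay on HepG2 cells (Homo sapiens) for cytotoxicity (a higher number here means that more compound is tolerated, a lower number that less compound is tolerated), and they lie within the scatter of each other, so compound 1 stands level with compound 2, which gives 20000 nM. Compound 3 `O=C(NC1CCCC1)C1CN(c2ccc(C(F)(F)F)cc2)CC(=O)N1c1cnc2ccsc2c1` keeps the core of compound 2 and carries one change: a group of 9 heavy atoms (7 carbon, 1 nitrogen, 1 sulfur; one five-membered aromatic ring with 1 hetero atom, one six-membered aromatic ring with 1 hetero atom) in place of a group of 9 heavy atoms (8 carbon, 1 oxygen; one five-membered aromatic ring with 1 hetero atom, one six-membered aromatic ring of carbon only), on an amide-type nitrogen in a ring. Within the data shown here, the only measured step at this place, on an amide-type nitrogen in a ring, is a 2.0-fold higher number from compound 1 to compound 2 (0.30 log units; within the scatter). Among the measured compounds shown here, that single step exchanged a different pair of groups, and no measured compound carries the entering group. A step beyond the scatter is therefore not expected in this assay, and no direction can be expected with confidence. The expected step is a 1.3-fold lower number from compound 2 to compound 3 (0.12 log units; within the scatter). For compound 3 the estimated value is 15000 nM, with an expected range from 6000 nM to 40000 nM.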

Compound 3, half-maximal cytotoxic concentration: 30000 nM
Beside the measured number, compound 3's estimate is 2.0-fold (0.30 log units) below it; measured number inside the range.
By their numbers in this assay, from the lowest: compounds 1, 2 and 3 (each within the scatter of the next, the first and the last beyond it).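

At this place, on an amide-type nitrogen in a ring, this assay shows that a second heteroaromatic group can replace 1-benzofuran-6-yl, with a 1.5-fold higher number from compound 2 to compound 3 (0.18 log units; within the scatter). Among the three groups seen here, only the pair of 3-(methylsulfanyl)phenyl and the group entering in compound 3 separates, with a 3.0-fold higher number from compound 1 to compound 3 (0.48 log units; beyond the scatter), a modest step and the first here to lie beyond the scatter. No measurement available here accounts for either step.

The compounds shown leave open whether a group carrying an amine or a carboxylic acid at this place would stay level with these or fall outside their range. From the compounds shown here alone, all three compounds keep the cyclopentylcarbamoyl and 4-(trifluoromethyl)phenyl groups, so what changes at those places would do remains unknown.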